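The compounds below may be only part of what the source reports. "The series", "measured", "known", "first", "only" and "open" are said of these compounds alone.

Measured compounds:
compound 1 `CCC(C(=O)N1CCN(c2ccc(C(F)(F)F)cc2)CC1)N1C(=O)CCC1=O`
compound 2 `CCC(C(=O)N1CCN(c2ccc(F)cc2)CC1)N1C(=O)CCC1=O`
compound 3 `CC(C(=O)N1CCN(c2ccc(F)cc2)CC1)N1C(=O)CCC1=O`

In a functional assay on the whole organism (strain Swiss) with Mus musculus as the target, in the maximal electroshock model, with a stated time of 0.5 h, at a dose of 300 mg/kg by the intraperitoneal route (on this read-out lower numbers stand for a weaker effect and higher numbers for a stronger effect at the one dose given), compound 1 gives 0%, compound 2 gives 25% and compound 3 gives 50%. Compound 2 stands second of the three numbers, with compound 1 lower and compound 3 higher, both beyond the scatter. Compound 4 `CCC(C(=O)N1CCN(c2cccc(C)c2)CC1)N1C(=O)CCC1=O` differs from compound 2 in one place: 3-methylphenyl in place of 4-fluorophenyl on an amine nitrogen in a ring. Of the measured steps only a number 25 percentage points higher from compound 1 to compound 2 (beyond the scatter) touches that aromatic ring, a modest step; a number 25 percentage points higher from compound 2 to compound 3 (beyond the scatter) lies on the saturated chain and does not bear on the change. Among the compounds with values here, no measured step replaces fluoro with methyl on that ring, so the direction is open and a step within the scatter, or a small one either way, is expected: no change at the digits printed from compound 2 to compound 4 (within the scatter). Compound 4 is therefore estimated at 25%, range 0% to 50%.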

Compound 4, a percentage reported as activity, at one dose (the size of the read-out at that dose, not a potency): 100%
Estimate against measurement, compound 4: 75 percentage points below; measured number above the stated range.
By their numbers in this assay, from the lowest: compound 1; then compound 2; then compound 3; then compound 4.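

In this assay, 3-methylphenyl in place of 4-fluorophenyl on the amine nitrogen in a ring gives a number 75 percentage points higher from compound 2 to compound 4 (beyond the scatter), a large step, where a number 25 percentage points higher from compound 1 to compound 2 (beyond the scatter) at the same place was modest. The aromatic group at this position can therefore shift the read-out much further than the earlier pair showed. Nothing available gives a reason for this step.

Open, on these data alone, is whether the step follows the methyl group itself or its place on the aromatic ring, as the two groups differ in both. Also open, as far as these compounds go, is how a chloro or methoxy group on that ring would read.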